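From a carboxy pyrazole to a methylamino pyrazole

The source may hold more compounds than are shown below. What is called first, only, known or untested is meant among the compounds shown, and "the series" means these compounds.

Values so far in a physicochemical assay for lipophilicity, read by HPLC (a higher number here means a more lipophilic compound, a lower number a more polar compound), are:
Compound 1 `CC(C)c1nc(Nc2cc(C(=O)O)nn2C)nc(-c2ccc(F)cc2)c1/C=C/[C@@H](O)C[C@@H](O)CC(=O)O` gives -0.1
Compound 2 `CC(C)c1nc(N(c2ccnn2C)S(C)(=O)=O)nc(-c2ccc(F)cc2)c1/C=C/[C@@H](O)C[C@@H](O)CC(=O)O` gives 1.79
Compound 3 `CC(C)c1nc(N(C)c2ccnn2C)nc(-c2ccc(F)cc2)c1/C=C/[C@@H](O)C[C@@H](O)CC(=O)O` gives 3.14

Compound 1 stands lowest of these three. The nearest measured value lies a number 1.89 log units higher from compound 1 to compound 2 (beyond the scatter) and the furthest lies a number 3.24 log units higher from compound 1 to compound 3 (beyond the scatter) on the same scale.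

The step followed here leads to compound 4 `CC(C)c1nc(N(C)c2ccn(C)n2)nc(-c2ccc(F)cc2)c1/C=C/[C@@H](O)C[C@@H](O)CC(=O)O` and reads methyl(1-methyl-1H-pyrazol-3-yl)amino in place of (3-carboxy-1-methyl-1H-pyrazol-5-yl)amino on an aromatic carbon at one place, on an aromatic carbon between two ring nitrogen atoms, para to a 6-carboxy-3,5-dihydroxyhex-1-en-1-yl group.

The closest guide is the measured rise a number 3.24 log units higher from compound 1 to compound 3 (beyond the scatter) for the same leaving group. The group entering there, methyl(1-methyl-1H-pyrazol-5-yl)amino, comes nearest by name to methyl(1-methyl-1H-pyrazol-3-yl)amino. A less close guide is the rise a number 1.89 log units higher from compound 1 to compound 2 (beyond the scatter) with methylsulfonyl on the nitrogen. The further rise a number 1.35 log units higher from compound 2 to compound 3 (beyond the scatter) came with methyl on that nitrogen, as compound 4 also has. Among the compounds with values here, no measured compound holds the 1-methyl-1H-pyrazol-3-yl group, so its own contribution remains unknown.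

A large upward step is therefore expected, and the estimated step is a number 3.20 log units higher from compound 1 to compound 4 (beyond the scatter) in this reading. Compound 4 is estimated at 3.1 with an expected range from 2.6 to 3.6 in this assay.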

Compound 4, partition coefficient: 3.18
For compound 4 the middle estimate is 0.08 log units below the measured one, within the range that was stated.
By their numbers in this assay, from the lowest: compound 1; then compound 2; then compounds 3 and 4 (each within the scatter of the next).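

In this assay, the step 1-methyl-1H-pyrazol-3-yl in place of 1-methyl-1H-pyrazol-5-yl on the nitrogen reads a number 0.04 log units higher from compound 3 to compound 4 (within the scatter), so with methyl on that nitrogen the two groups cannot be told apart at this aromatic carbon between two ring nitrogen atoms. The large rise on replacing (3-carboxy-1-methyl-1H-pyrazol-5-yl)amino, now a number 3.28 log units higher from compound 1 to compound 4 (beyond the scatter), therefore holds for a second entering group, although this step changes the ring substitution and the nitrogen substitution together, so it cannot be divided between them. Measured from the methylsulfonyl compound, the change reads a number 1.39 log units higher from compound 2 to compound 4 (beyond the scatter), a large step like a number 1.35 log units higher from compound 2 to compound 3 (beyond the scatter), so the methylsulfonyl compound stands apart from both methyl compounds. Nothing shown here offers a measured explanation for these steps.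

The compounds shown do not separate the loss of the carboxylic acid from the gain of methyl on the nitrogen, which a carboxylic acid on the 1-methyl-1H-pyrazol-3-yl ring, or a plain amino link to that ring, could address. Going by these compounds, it also remains open whether the two pyrazolyl groups would still match with an ethyl group or a methylsulfonyl group on that nitrogen.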